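The source may report more compounds than this note shows. Statements on the series, on what has been measured and on what is new or still open speak of the compounds shown alone.

Measured compounds:
compound 1 `CC1CCN(c2c(S(=O)(=O)c3ccccc3)cnc3ccc(Cl)cc23)CC1` — 59%
compound 2 `COc1cccc(S(=O)(=O)c2cnc3ccc(Cl)cc3c2N2CCC(C)CC2)c1` — 87%
compound 3 `Cc1ccc2ncc(S(=O)(=O)c3ccccc3)c(N3CCC(C)CC3)c2c1` — 67%

In an assay on isolated protein for displacement of a labelled ligand from metabotropic glutamate receptor 5 (Homo sapiens), with a stated time of 60 min, tested at 1 uM (on this read-out lower numbers stand for less inhibition and higher numbers for more inhibition at the one concentration tested (going by the name of the read-out)), compound 1 gives 59%, compound 2 gives 87% and compound 3 gives 67%. Compound 4 `COc1cccc(S(=O)(=O)c2cnc3ccc(C)cc3c2N2CCC(C)CC2)c1` has not been measured.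

The change that separates compound 1 from compound 2 is methoxy in place of hydrogen on an aromatic carbon, and it brought a number 28 percentage points higher from compound 1 to compound 2 (beyond the scatter). The change that separates compound 3 from compound 4 is methoxy in place of hydrogen on an aromatic carbon; the place lines of the two changes are the same word for word, so this is the same change made on a different core. The two cores differ as methyl in place of chloro on an aromatic carbon, a change that gave a number 8 percentage points higher from compound 1 to compound 3 (within the scatter), so compound 3 and compound 1 sit within the scatter of each other in this assay.

Among the compounds with values here, only one example of the methoxy step is known, and it was made on the core of compound 1. Because compound 3 gave 67%, close to compound 1, the same step on the core of compound 3 is expected to be of a similar size, the read-out being a percentage at one concentration; the expected step is a number 21 percentage points higher from compound 3 to compound 4 (beyond the scatter). Compound 4 is therefore estimated at 88% in this assay, with a range from 74% to 97%.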

Compound 4, a percentage reported as inhibition, at one concentration (the size of the read-out at that concentration, not a potency): 96%
For compound 4 the middle estimate is 8 percentage points below the measured one, and the stated range covers the measured number.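

In this assay, the phenyl to 3-methoxyphenyl change carries from the core of compound 1 to the core of compound 3 with no detectable loss, giving a number 29 percentage points higher from compound 3 to compound 4 (beyond the scatter), and the two steps agree: the same change on two cores in this assay, a number 28 percentage points higher (beyond the scatter) from compound 1 to compound 2 and a number 29 percentage points higher (beyond the scatter) from compound 3 to compound 4, 1 percentage points apart, within the scatter of two such steps

The methyl in place of chloro change, which gives a number 9 percentage points higher from compound 2 to compound 4 (within the scatter), also reads alike with and without the methoxy group: the same change on two cores in this assay, a number 8 percentage points higher (within the scatter) from compound 1 to compound 3 and a number 9 percentage points higher (within the scatter) from compound 2 to compound 4, 1 percentage points apart, within the scatter of two such steps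

These four compounds form a single closed square, so the agreement shows that the two changes add up on these cores in this assay, but it does not show that either step holds on a core altered elsewhere, and a percentage at one concentration is not a potency.

The compounds shown leave open whether ethoxy, a longer chain or an amine in place of methoxy would give a step of similar size, and whether methoxy elsewhere on the same six-membered aromatic ring of carbon only would do the same. They also leave open how a nitrile or a carboxylic acid in place of the chloro or methyl group would read in this assay.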